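The source may report more compounds than this note shows. Statements on the series, on what has been measured and on what is new or still open speak of the compounds shown alone.

Measured in an ADME assay on BCBL1 cells (Homo sapiens) for cytotoxicity, with a stated time of 7 days; on this read-out higher numbers stand for lower toxicity in this test and lower numbers for higher toxicity in this test:
compound 1 `Nc1nc(NC2CC2)c2ncn(/C=C3/CC3(CO)CO)c2n1` gives 71500 nM.
compound 2 `CC(C)CNc1nc(N)nc2c1ncn2/C=C1/CC1(CO)CO` gives > 20000 nM, a limit of the assay.
compound 3 `CCCOc1nc(N)nc2c1ncn2/C=C1/CC1(CO)CO` gives > 20000 nM, a limit of the assay.

Compound 2 therefore stands only at a limit in this assay, and two of the three measured values sit at that limit (the limit of > 20000 nM in this assay, at which 2 of the 3 values shown sit). Compound 4 `Nc1nc(NC2CCCC2)c2ncn(/C=C3/CC3(CO)CO)c2n1` differs from compound 2 by cyclopentyl in place of isobutyl on a nitrogen on an aromatic ring. Within the data shown here, the one measured step into compound 2, a step that the limit leaves unreadable from compound 1 to compound 2, cannot be read, and neither can a step that the two limits leave unreadable from compound 2 to compound 3 nor a step that the limit leaves unreadable from compound 1 to compound 3. Among the measured compounds shown here, compound 1, which carries cyclopropyl on a nitrogen on an aromatic ring, is the only one giving a number rather than a limit. Compound 4 is expected to stay at or near the limit, with an expected step that the limit leaves unreadable from compound 2 to compound 4 that should not pass beyond the scatter. Compound 4 is estimated at 50000 nM, within 20000 nM to 150000 nM.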

Compound 4, half-maximal cytotoxic concentration: 71700 nM
Compound 4: middle estimate off by 1.4-fold (0.16 log units), on the low side, within the range that was stated.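

In this assay, the change of ring on the nitrogen gives a 1.0-fold higher number from compound 1 to compound 4 (0.00 log units; within the scatter), so compound 4 is the second compound here with a number rather than a limit. At this position the two rings read alike. The other new steps cannot be read, because compound 2 and compound 3 give only limits: the limit of > 20000 nM in this assay, at which 2 of the 4 values shown sit.

From the compounds shown here alone, how the isobutyl of compound 2 compares with these rings stays open. So does how a phenyl or a hydroxyethyl group on the same nitrogen would read.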